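This account rests on a few compounds, and the source may have more. Where it says the series, first, only, none or still open, it means among the compounds named here.

Measured so far in a functional assay on HeLa cells (Homo sapiens) for inhibition; a lower number here means a stronger inhibitor, a higher number a weaker inhibitor:
compound 1 `COC(=O)C(C(=O)OC)C1CC(=O)C=CC12OCC(=O)N2Cc1ccc(C)cc1` gives 410 nM.
compound 2 `COC(=O)C(C(=O)OC)C1CC(=O)C=CC12OCC(=O)N2Cc1ccc(Cl)cc1` gives 180 nM.
compound 3 `CCSC1CC(=O)CC(SCC)C12OCC(=O)N2Cc1ccc(C)cc1` gives 2410 nM.

Compound 4 `CCSC1CC(=O)CC(SCC)C12OCC(=O)N2Cc1ccc(Cl)cc1` is not yet measured in this assay. Compound 4 differs from compound 3 by chloro in place of methyl on an aromatic carbon. The same change, (chloro in place of methyl on an aromatic carbon), has been measured once between two compounds of the other core: a 2.3-fold lower number from compound 1 to compound 2 (0.36 log units; beyond the scatter). The difference between the two cores is not broken down here; the values show that compound 3 gives a higher number than compound 1. The place of the change reads the same word for word in both pairs, so this is the same kind of change at the same kind of place. Going by the values given here, with only one earlier step known, a step of similar size is expected in this assay, resting on a 2.3-fold lower number from compound 1 to compound 2 (0.36 log units; beyond the scatter): the expected step is a 2.2-fold lower number from compound 3 to compound 4 (0.34 log units; beyond the scatter). Compound 4 is estimated at 1100 nM, between 500 nM and 2500 nM.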

Compound 4, half-maximal inhibitory concentration: 3920 nM
For compound 4 the middle estimate is 3.6-fold (0.55 log units) below the measured one; the whole stated range lies below it.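

Chloro in place of methyl on an aromatic carbon gives a 1.6-fold higher number from compound 3 to compound 4 (0.21 log units; within the scatter) in this assay. The step measured on the core of compound 1 therefore does not carry over to the core of compound 3: the same change on two cores in this assay, a 2.3-fold lower number (0.36 log units; beyond the scatter) from compound 1 to compound 2 and a 1.6-fold higher number (0.21 log units; within the scatter) from compound 3 to compound 4, 3.7-fold (0.57 log units) apart, beyond the scatter of two such steps. This rests on a single pair per core, so it shows that the change cannot be transferred between these two cores, but not which part of the cores accounts for the gap or how the change would behave on a third core.

Still open, going by these compounds, is whether a methoxy or a nitrile at the same place would also differ between the two cores. Also open, on these data alone, is how the step would run with an amine or a carboxylic acid in place of the ethylthio groups of compound 3.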